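The compounds below may be only part of what the source reports. "The series", "measured", "known", "first", "only" and "open" are said of these compounds alone.

Compound 2 `O=C(c1ccccc1Cl)N1N=C(c2cc3ccccc3oc2=O)CC1c1ccccc1` is one of two pyrazoline-type entries measured in a functional assay on HepG2 cells (Homo sapiens) for cytotoxicity, read by MTT assay, with a stated time of 48 h (on this read-out lower numbers stand for stronger inhibition and higher numbers for weaker inhibition), where compound 2 gives 5440 nM. Compound 1 `CC1=NN(C(=O)CN2CCCCC2)C(c2ccccc2O)C1`, built on a different core, gives 3020 nM in this assay, and the two values sit within the usual scatter of each other, so neither can be placed above the other. The next compound, compound 3 `CC1CCCCN1CC(=O)N1N=C(c2cc3ccccc3oc2=O)CC1c1ccccc1`, differs from compound 2 by (2-methylpiperidin-1-yl)methyl in place of 2-chlorophenyl on a carbonyl carbon. Within the data shown here, with no measured step of this kind to draw on, the change is expected to give a step of a 1.4-fold lower number from compound 2 to compound 3 (0.13 log units; within the scatter) that stays within the scatter. Compound 3 is therefore expected to give 4000 nM, with a range from 1500 nM to 12000 nM.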

Compound 3, half-maximal inhibitory concentration: "not active" (no number reported)
No number was reported for compound 3, so the estimate cannot be set against anything.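

Among these compounds, compound 3 is reported only as "not active" in this assay, without a number, so no step from compound 2 to compound 3 can be read. The compounds shown leave open how large the effect of replacing 2-chlorophenyl with (2-methylpiperidin-1-yl)methyl is, and nothing shown offers an explanation for this result.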